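The compounds below may be only part of what the source reports. "The series", "measured", "known", "first", "only" and "open" are said of these compounds alone.

Three compounds share one core and differ only in the group on the carbonyl carbon of the side chain. Compound 1 `CC(Br)C(=O)Nc1cc(C(=O)NC(N)=O)ccc1F` carries a 1-bromoethyl group, and in a functional assay on CCRF-CEM cells (Homo sapiens) for antiproliferative activity, read by trypan blue exclusion, with a stated time of 72 h (on this read-out lower numbers stand for stronger inhibition and higher numbers for weaker inhibition), compound 1 gives 3130 nM. Compound 2 `NC(=O)NC(=O)c1ccc(F)c(NC(=O)CBr)c1` has hydrogen in place of methyl on that chain carbon, and in this assay compound 2 gives 2290 nM; the change is a 1.4-fold lower number from compound 1 to compound 2 (0.14 log units; within the scatter). Compound 3 `NC(=O)NC(=O)c1ccc(F)c(NC(=O)CCl)c1` carries a chloromethyl group instead. In this assay compound 3 reports only a limit, > 20000 nM, so its true number is not known. The two steps into compound 3, an at least 6.3-fold higher number from compound 1 to compound 3 (0.80 log units; beyond the scatter) and an at least 8.7-fold higher number from compound 2 to compound 3 (0.94 log units; beyond the scatter), both weaken inhibition, and compound 3 sits at the limit of > 20000 nM in this assay, at which 1 of the 3 values shown sits.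

Compound 4 `NC(=O)NC(=O)c1ccc(O)c(NC(=O)CCl)c1` keeps the chloromethyl group and changes the ring: hydroxy in place of fluoro on an aromatic carbon. Going by the values given here, none of the three measured steps touches the ring; each concerns the halogen or the chain on the carbonyl carbon, so no measured step bears directly on this change. Among the compounds with values here, with no such step to lean on, the expectation for compound 4 is a step of a number no higher from compound 3 to compound 4 (the limit leaves the size open), nothing beyond the scatter. Compound 4 is therefore estimated at 20000 nM, with a range from 7000 nM to 60000 nM, and a limit again seems the most likely report.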

Compound 4, half-maximal inhibitory concentration: > 20000 nM
Compound 4 was reported as a limit; the forecaster's own chance of this, stated with the estimate: 70%; the middle value sits exactly at the limit.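

In this assay compound 3 and compound 4 are both reported only as limits, so the step between them cannot be read: the limit of > 20000 nM in this assay, at which 2 of the 4 values shown sit.

The compounds shown leave open whether hydroxy in place of fluoro on this aromatic carbon changes inhibition at all and, if it does, in which direction.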